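Aryl variation on the triazole nitrogen in a spiro series

The source may report more compounds than this note shows. Statements on the series, on what has been measured and on what is new or still open speak of the compounds shown alone.

Measured compounds:
- compound 1 `N#CC1=C(N)Oc2c(c3nc4ccccc4nc3c3ccccc23)C12C(=O)N(Cc1cnnn1-c1cccc(S(N)(=O)=O)c1)c1ccccc12`: in a functional assay on MCF7 cells (Homo sapiens) for antiproliferative activity, read by MTT assay, with a stated time of 48 h (a lower number here means a stronger inhibitor, a higher number a weaker inhibitor), compound 1 gives 42500 nM
- compound 2 `Cc1ccc(Cl)cc1-n1nncc1CN1C(=O)C2(C(C#N)=C(N)Oc3c2c2nc4ccccc4nc2c2ccccc32)c2ccccc21`: in this assay compound 2 reports only the assay limit, > 50000 nM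

Compound 2 stands at the assay limit (the limit of > 50000 nM in this assay, at which 1 of the 2 values shown sits), so its number is a bound, not a measurement. The next compound, compound 3 `N#CC1=C(N)Oc2c(c3nc4ccccc4nc3c3ccccc23)C12C(=O)N(Cc1cnnn1-c1ccc(Cl)c(Cl)c1)c1ccccc12`, carries the change (3,4-dichlorophenyl in place of 5-chloro-2-methylphenyl on an aromatic nitrogen). For the measured compounds named here, the only measured step that touches this position is an at least 1.1-fold higher number from compound 1 to compound 2 (0.07 log units; that floor lies within the scatter), which itself rests on the limit and lies within the scatter. No step beyond the scatter is therefore expected for compound 3 in this assay, and its step from compound 2 is estimated as a step that the limit leaves unreadable from compound 2 to compound 3. Compound 3 is expected at about 60000 nM, within 25000 nM to 150000 nM, with a real chance that only a limit is reported again.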

Compound 3, half-maximal inhibitory concentration: > 50000 nM
Compound 3: only a limit was reported; the forecaster's own chance of this, stated with the estimate: 60%; the middle value does not contradict the limit.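

In this assay, a second chlorine-bearing phenyl group, 3,4-dichlorophenyl, also ends at a limit rather than a number: the limit of > 50000 nM in this assay, at which 2 of the 3 values shown sit. Exchanging 3-sulfamoylphenyl for it gives an at least 1.1-fold higher number from compound 1 to compound 3 (0.07 log units; that floor lies within the scatter), a floor that rests on that limit. The step between compound 2 and compound 3 cannot be read, so the two chlorine patterns cannot be ranked.

On these data alone, whether any group on this nitrogen brings the number clearly below the limit remains open. An aminophenyl group, a carboxyphenyl group or a longer alkyl chain in place of the aryl ring would address this.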